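A few compounds are considered here, and "the series" means these few. Any claim that something is new, unique, unknown or untested is made for them only; others in the source may bear on it.

The set rests on a shared core bearing a 4-hydroxyphenyl group and a 4-chlorophenyl group. Compound 1 `Oc1ccc(-c2cc(-c3ccncc3)nc(-c3ccc(Cl)cc3)c2)cc1` was taken into a functional assay on DU-145 cells (Homo sapiens) for cytotoxicity, read by CCK-8 assay and cell counting, with a stated time of 2 days (on this read-out lower numbers stand for stronger inhibition and higher numbers for weaker inhibition), where compound 1 stands as "not determined" (no result reported), with no result reported for it. Going by the values given here, compound 2 `Oc1ccc(-c2cc(-c3ccc(Cl)cc3)nc(-c3cccnc3)c2)cc1` gives 22800 nM in this assay, and this is the only number in the set; nothing else stands beside it, so no step between measured compounds can be read off. Compound 3 `Oc1ccc(-c2cc(-c3ccc(Cl)cc3)nc(-c3ccsc3)c2)cc1` differs from compound 2 in a single place: thiophen-3-yl in place of pyridin-3-yl on an aromatic carbon. Among the compounds with values here, with no measured step to lean on, the size of the coming change is an expectation only; a small step is expected, in neither direction clearly, and most likely not beyond the usual scatter, a 1.1-fold lower number from compound 2 to compound 3 (0.06 log units; within the scatter). Compound 3 is accordingly estimated to give 20000 nM in this assay, with a range from 7000 nM to 55000 nM.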

Compound 3, half-maximal inhibitory concentration: 6940 nM
For compound 3 the middle estimate is 2.9-fold (0.46 log units) above the measured one; the measured number lies below the stated range.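

Going by these compounds alone, this is the first step in the set that can be read, and it shows that in this assay the position next to the ring nitrogen is sensitive to which aromatic ring it carries: putting thiophen-3-yl in place of pyridin-3-yl gives a 3.3-fold lower number from compound 2 to compound 3 (0.52 log units; beyond the scatter). The exchange of a six-membered aromatic ring for a five-membered one is thus compatible with a stronger read-out here, at least for this pair. Nothing available bears on why the number moves.

From the compounds shown here alone, whether a furan-3-yl or a plain phenyl group on this aromatic carbon would read closer to compound 2 or to compound 3 stays open. So does how an amine or a longer chain at the same place would read in this assay.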